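Sulfonyl substituents: the step from compound 3 to compound 4

The source may hold more compounds than are shown below. What is called first, only, known or untested is meant among the compounds shown, and "the series" means these compounds.

compound 1 `O=C(NCc1ccc(S(=O)(=O)c2cccc(C(F)(F)F)c2)cc1)N1Cc2ccncc2C1` gives 2.7 nM
compound 2 `CC(=O)N1CCC(S(=O)(=O)c2ccc(CNC(=O)N3Cc4ccncc4C3)cc2)CC1` gives 110 nM
compound 3 `CN1CCC(S(=O)(=O)c2ccc(CNC(=O)N3Cc4ccncc4C3)cc2)CC1` gives 99 nM

All three values come from a functional assay on A2780 cells (Homo sapiens) for cytotoxicity, read by sulforhodamine B assay, with a stated time of 72 h; on this read-out lower numbers stand for stronger inhibition and higher numbers for weaker inhibition. In this assay compound 3 gives 99 nM, which places it level with compound 2 and well apart from compound 1. The two saturated rings therefore form one group, and the aromatic sulfone stands alone.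

The next compound is compound 4 `CN1CCN(S(=O)(=O)c2ccc(CNC(=O)N3Cc4ccncc4C3)cc2)CC1`, not yet measured. The change is 4-methylpiperazin-1-yl in place of 1-methylpiperidin-4-yl on a sulfonyl sulfur, with 4-methylpiperazin-1-yl in place of 1-methylpiperidin-4-yl on a sulfonyl sulfur.

Two measured steps show that swapping the aromatic group for a saturated ring counts heavily: a 41-fold higher number from compound 1 to compound 2 (1.61 log units; beyond the scatter) and a 37-fold higher number from compound 1 to compound 3 (1.56 log units; beyond the scatter). These steps do not resemble the present change closely, since compound 4 keeps a saturated six-membered ring. The nearer guide is a 1.1-fold lower number from compound 2 to compound 3 (0.05 log units; within the scatter), a change on the ring nitrogen that left the number essentially unmoved. For the measured compounds named here, no measured step alters the ring atom attached to the sulfonyl sulfur, so this guide is indirect and the range must stay wide.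

No step beyond the scatter is expected in this assay, in either direction. The expected change is a 1.2-fold lower number from compound 3 to compound 4 (0.09 log units; within the scatter). For compound 4 the estimated value is 80 nM. The expected range for compound 4 runs from 25 nM to 250 nM.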

Compound 4, half-maximal inhibitory concentration: 71 nM
Compound 4: the middle estimate sits 1.1-fold (0.05 log units) above what was measured; measured number inside the range.
By their numbers in this assay, from the lowest: compound 1; then compounds 4, 3 and 2 (each within the scatter of the next).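

In this assay, for the compounds shown here, a six-membered non-aromatic ring with 2 hetero atoms is accepted on the sulfonyl sulfur in place of one with 1 hetero atom, a change no earlier pair covered: a 1.4-fold lower number from compound 3 to compound 4 (0.14 log units; within the scatter), and a 1.5-fold lower number from compound 2 to compound 4 (0.19 log units; within the scatter). The group of saturated rings therefore grows to three members, all still far from the aromatic sulfone, with a 26-fold higher number from compound 1 to compound 4 (1.42 log units; beyond the scatter), and none of the compounds shown goes against this split. No measured evidence bears on why the ring change leaves the number within the scatter or why the aromatic sulfone stands apart.

Going by these compounds, it remains open whether the gap to compound 1 belongs to the aromatic ring itself or to its trifluoromethyl group, a question that a plain phenyl or a 3-chlorophenyl on the sulfonyl sulfur would address. Also open, on these data alone, is whether the saturated group stays level with these three when the ring nitrogen carries only hydrogen, as in piperazin-1-yl, or when morpholin-4-yl stands on the sulfonyl sulfur.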